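Benzyl substitution on the shared core: chloro in place of hydrogen

The compounds below may be only part of what the source reports. "The series", "measured", "known", "first", "only" and "open" are said of these compounds alone.

Measured so far:
Compound 1, `O=C(C1CC1)N1CCN(Cc2nc3ccccc3n2Cc2ccccc2C(F)(F)F)CC1` — 56.3%
Compound 2, `O=C(C1CC1)N1CCN(Cc2nc3ccccc3n2Cc2ccccc2)CC1` — 23.9%

In an assay on isolated protein for inhibition of aldehyde dehydrogenase 1A1 (Homo sapiens), read by spectrophotometry, tested at 10 uM (a lower number here means less inhibition, a higher number more inhibition at the concentration tested (going by the name of the read-out)), compound 2 gives 23.9%, the lowest of the two numbers shown. For the measured compounds named here, its nearest neighbour is compound 1, a number 32.4 percentage points lower from compound 1 to compound 2 (beyond the scatter), the only step recorded in this assay.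

Compound 3, `O=C(C1CC1)N1CCN(Cc2nc3ccccc3n2Cc2ccc(Cl)cc2)CC1`, is not yet measured. It differs from compound 2 by chloro in place of hydrogen on an aromatic carbon, on the same six-membered ring of carbon only that carries the trifluoromethyl in compound 1, though at a different aromatic carbon.

Going by the values given here, no measured step has a chloro entering; the one step at hand is a number 32.4 percentage points lower from compound 1 to compound 2 (beyond the scatter), which shows that a substituent on this ring can move the number well beyond the scatter. A chlorine is a smaller change than trifluoromethyl and sits at another place, so a smaller rise is expected: a number 12.1 percentage points higher from compound 2 to compound 3 (beyond the scatter).

For compound 3 the estimate in this assay is 36%, with a range from 15% to 60%.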

Compound 3, a percentage reported as inhibition, at one concentration (the size of the read-out at that concentration, not a potency): 56.6%
Beside the measured number, compound 3's estimate is 20.6 percentage points below it; low and high end bracket the measured number.
By their numbers in this assay, from the lowest: compound 2; then compounds 1 and 3 (each within the scatter of the next).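

In this assay, 4-chlorobenzyl in place of benzyl gives a number 32.7 percentage points higher from compound 2 to compound 3 (beyond the scatter), so on this ring a single chlorine, para to a large group, is enough for a large step, and that step is not confined to trifluoromethyl. The change between the two substituted benzyl groups gives a number 0.3 percentage points higher from compound 1 to compound 3 (within the scatter), so 4-chlorophenyl and 2-(trifluoromethyl)phenyl cannot be told apart here, although they differ in both group and ring place. No measurement at hand accounts for the chloro step.

With each substituent shown at only one ring place, the compounds leave open how much of the step follows the group and how much follows its place. Also open, as far as these compounds go, is how a methoxy, an amine or a carboxylic acid would read at the place now held by chloro.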